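Aryl triazene series: Vero cytotoxicity, bromo to nitro

The compounds below may be only part of what the source reports. "The series", "measured", "known", "first", "only" and "open" are said of these compounds alone.

Working notes on a small set of aryl triazenes. In an ADME assay on Vero cells (Chlorocebus sabaeus) for cytotoxicity, read by crystal violet staining (on this read-out lower numbers stand for higher toxicity in this test and higher numbers for lower toxicity in this test), compound 1 `Brc1cccc(/N=N/N2CCCCC2)c1` gives 85000 nM. Compound 2 `O=[N+]([O-])c1cccc(/N=N/N2CCCC2)c1`, which carries a nitro group and a smaller saturated ring, gives in this assay a value of 80000 nM; the two numbers lie within the usual scatter of each other, so nothing separates compound 1 from compound 2 on this read-out. Compound 3 `O=[N+]([O-])c1cccc(/N=N/N2CCCCC2)c1` has not yet been measured in this assay. It differs from compound 1 in one place: nitro in place of bromo on an aromatic carbon. For the measured compounds named here, no measured pair in the set isolates this exchange, so the size of the step rests on expectation only. Since compound 2, which also carries a nitro group, gives 80000 nM in this assay, the step of a 1.1-fold lower number from compound 1 to compound 3 (0.03 log units; within the scatter) is expected to stay within the scatter, with no clear direction. Compound 3 is therefore estimated at 80000 nM, with a range of 40000 nM to 160000 nM.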

Compound 3, half-maximal cytotoxic concentration: 83000 nM
The estimate for compound 3 lay 1.0-fold (0.02 log units) below the measured number, within the range that was stated.
By their numbers in this assay, from the lowest: compounds 2, 3 and 1 (each within the scatter of the next).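

The exchange of nitro for bromo on an aromatic carbon can now be read on its own: in this assay it gives a 1.0-fold lower number from compound 1 to compound 3 (0.01 log units; within the scatter) and so does not separate the two groups on this read-out. At this position of the core of compound 1, the two groups are therefore not told apart by this cytotoxicity measure, although they differ in heavy atoms and hydrogen-bond acceptors as counted. Nothing among the available data bears on why they read alike.

As far as these compounds go, whether an amine or a carboxylic acid at this position would also stay within the scatter of compound 1 remains open. Also open, from the compounds shown here alone, is how a longer chain on the saturated ring would read in this assay on the same core.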